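Butyl in Place of Cyclopentyl on the Amide-Type Nitrogen

The source may report more compounds than this note shows. Statements on the series, on what has been measured and on what is new or still open speak of the compounds shown alone.

Measured so far:
compound 1 `O=C(NC1CCCCC1)Oc1cccc(-c2ccccc2)c1`: 41.1%
compound 2 `O=C(NC1CCCC1)Oc1cccc(-c2ccccc2)c1`: 34.4%
compound 3 `O=C(NCc1ccc2ccccc2c1)Oc1cccc(-c2ccccc2)c1`: 18.4%

In a physicochemical assay, read by HPLC, in phosphate buffer, at pH 7.0 (a higher number here means that more of the compound is left, a lower number that less of the compound is left), compound 2 gives 34.4%, the second highest of the three numbers. Compound 1 stands within the scatter of it, and compound 3 stands beyond the scatter below it. Compound 4 `CCCCNC(=O)Oc1cccc(-c2ccccc2)c1` carries a single change against compound 2: butyl in place of cyclopentyl on an amide-type nitrogen. For the measured compounds named here, the one measured step on that nitrogen, a number 6.7 percentage points lower from compound 1 to compound 2 (within the scatter), swapped one ring for another and stayed within the scatter; no measured step opens the ring into a chain. No step beyond the scatter is therefore expected here. Compound 4 is estimated to give about 35%, in a range from 20% to 50%. The expected step is a number 0.6 percentage points higher from compound 2 to compound 4 (within the scatter).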

Compound 4, percent of the compound remaining: 46.7%
Compound 4: the middle estimate sits 11.7 percentage points below what was measured, and the stated range covers the measured number.
By their numbers in this assay, from the lowest: compound 3; then compounds 2, 1 and 4 (each within the scatter of the next, the first and the last beyond it).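

In this assay, for the compounds shown here, butyl in place of cyclopentyl gives the first step beyond the scatter on this amide-type nitrogen (a number 12.3 percentage points higher from compound 2 to compound 4 (beyond the scatter)). Butyl in place of cyclohexyl stays within the scatter (a number 5.6 percentage points higher from compound 1 to compound 4 (within the scatter)), so on this nitrogen the open chain of compound 4 keeps pace with the cyclohexyl ring of compound 1 but not with the cyclopentyl ring of compound 2. No available evidence bears on why these two steps differ. As far as these compounds go, whether a longer chain such as hexyl would keep this level remains open. So does the effect of an amine or a carboxylic acid at the end of the butyl chain.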